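Swapping the Naphthalenyl Group for a Fluorophenyl

The source may report more compounds than this note shows. Statements on the series, on what has been measured and on what is new or still open speak of the compounds shown alone.

In a functional assay on WM 266-4 cells (Homo sapiens) for antiproliferative activity, read by MTT assay, with a stated time of 24 h (on this read-out higher numbers stand for weaker inhibition of growth and lower numbers for stronger inhibition of growth), compound 1 `c1ccc(N2N=C(c3ccc4c(c3)OCCO4)CC2c2cccc3ccccc23)cc1` gives only a limit, > 100000 nM, and so stands at the weakest end of the numbers shown (the limit of > 100000 nM in this assay, at which 1 of the 2 values shown sits). Compound 2 `O=C(c1ccc2c(c1)OCCO2)N1N=C(c2ccc(Br)cc2)CC1c1ccccc1F` gives 750 nM in this assay. Compound 3 `Fc1ccccc1C1CC(c2ccc3c(c2)OCCO3)=NN1c1ccccc1` differs from compound 1 by 2-fluorophenyl in place of naphthalen-1-yl on a saturated ring carbon. For the measured compounds named here, no measured pair shows the effect of this change, so the size of the step is open; a gain in growth inhibition is expected, though a modest one that may still leave compound 3 at the limit. Compound 3 is estimated at 40000 nM in this assay, ranging from 5000 nM to 100000 nM, with an expected step of an at least 2.5-fold lower number from compound 1 to compound 3 (0.39 log units; beyond the scatter).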

Compound 3, concentration for 50% growth inhibition: 9120 nM
The estimate for compound 3 lay 4.4-fold (0.64 log units) above the measured number; measured number inside the range.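

In this assay, 2-fluorophenyl in place of naphthalen-1-yl on a saturated ring carbon brings an at least 10-fold lower number from compound 1 to compound 3 (1.04 log units; beyond the scatter), so the group at this position does bear on growth inhibition. The true size of this step stays unknown because compound 1 stands at a limit and not at a number: the limit of > 100000 nM in this assay, at which 1 of the 3 values shown sits.

The compounds shown leave open whether the fluorine or the loss of the second aromatic ring carries the gain, and a plain phenyl group on this carbon would separate the two. They also leave open how a methoxy group in place of the fluorine would fare.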